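Sulfate esters on two glycoside cores, thymidine incorporation

The compounds below may be only part of what the source reports. "The series", "measured", "known", "first", "only" and "open" are said of these compounds alone.

Compound 1 `C=CCCC(=O)N[C@H]1[C@@H](OCCc2ccccc2)O[C@H](CO)[C@@H](O)[C@@H]1O` carries a pentenamide on a phenethyl glycoside core. In a functional assay on C6 cells (Rattus norvegicus), read by thymidine incorporation (a higher number here means a weaker inhibitor, a lower number a stronger inhibitor), compound 1 gives > 50 uM, a limit of the assay and not a number. Compound 3 `C=CCCC(=O)N[C@H]1[C@@H](OCCc2ccccc2)O[C@H](CO)[C@@H](O)[C@@H]1OS(=O)(=O)O` differs from compound 1 by sulfo in place of hydrogen on an oxygen on a saturated carbon. In this assay compound 3 gives > 50 uM, again a limit. The step that the two limits leave unreadable from compound 1 to compound 3 cannot be read since (the limit of > 50 uM in this assay, at which 2 of the 3 values shown sit).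

Compound 2 `CCCCCCCC/C=C\CCCCCCCCO[C@H]1O[C@H](CO)[C@@H](O)[C@H](O)[C@H]1NC(C)=O` rests on another core; the difference between the two cores is not broken down here. In this assay, going by the values given here, compound 2 gives 1.3 uM, the only number in the set. Compound 4 `CCCCCCCC/C=C\CCCCCCCCO[C@H]1O[C@H](COS(=O)(=O)O)[C@@H](O)[C@H](O)[C@H]1NC(C)=O`, not yet measured, differs from compound 2 by sulfo in place of hydrogen on an oxygen on a saturated carbon. This is the same kind of change as from compound 1 to compound 3, but here the carbon's other neighbour is a saturated chain carbon rather than a saturated ring carbon. The earlier step offers no readable size to carry over. The step is expected to be a 2.3-fold higher number from compound 2 to compound 4 (0.36 log units; beyond the scatter), resting on compound 2 at 1.3 uM. Compound 4 is thus estimated at 3 uM, within 0.7 uM to 15 uM.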

Compound 4, concentration for 50% inhibition: 13 uM
Compound 4: middle estimate off by 4.3-fold (0.64 log units), on the low side; measured number inside the range.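

In this assay the change gives a 10-fold higher number from compound 2 to compound 4 (1.00 log units; beyond the scatter), so on the core of compound 2 the sulfo group goes with a weaker inhibitor, though compound 4 stays measurable. This is the only readable size for the change, and it comes from a single pair, with the sulfo group placed on an oxygen on a saturated carbon whose other neighbour is a saturated chain carbon. Whether the step carries from one core to the other is not shown, since the step on the core of compound 1 cannot be read and both of its ends are limits, not numbers: the limit of > 50 uM in this assay, at which 2 of the 4 values shown sit.

Going by these compounds, what a carboxylic acid or a phosphate in place of the sulfo group would do on the core of compound 2 stays open. So does the size of the step on that core with a shorter chain in place of the chain of compound 2.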